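The compounds below may be only part of what the source reports. "The series", "measured", "known", "first", "only" and "open" are said of these compounds alone.

Measured so far:
compound 1, `CCOc1cc(C(C)(C)C)ccc1C1=NC(c2ccc(Cl)cc2)C(c2ccc(Cl)cc2)N1C(=O)N1CCN(Cc2ccc(C(=O)NO)cc2)CC1`, 260 nM
compound 2, `CCOc1cc(C(C)(C)C)ccc1C1=NC(c2ccc(Cl)cc2)C(c2ccc(Cl)cc2)N1C(=O)NCCCCCCCC(=O)NO`, 340 nM

Both were read in an assay on isolated protein for inhibition of E3 ubiquitin-protein ligase Mdm2 (Homo sapiens), read by fluorescence polarization, with a stated time of 30 min; a higher number here means a weaker inhibitor, a lower number a stronger inhibitor. Compound 2 carries the higher of the two numbers, but its nearest neighbour is compound 1, and the gap between them sits within the scatter of the method, so no order between the two can be claimed; both share the same core and differ only in what hangs on the urea nitrogen, and on these two numbers that part of the molecule does not visibly move the read-out.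

Compound 3, `CCOc1cc(C(C)(C)C)ccc1C1=NC(c2ccc(Cl)cc2)C(c2ccc(Cl)cc2)N1C(=O)NCCCCCC(=O)Nc1ccccc1N`, is the next compound on the shared core and is not yet measured in this assay. It differs from compound 2 as follows: (2-aminophenyl)carbamoyl in place of 2-(hydroxycarbamoyl)ethyl on a saturated chain carbon, five bonds along the chain from an amide-type nitrogen. Among the compounds with values here, no measured pair shows this change, so its size has to be estimated. Since the two measured variations of the chain gave numbers within the scatter of each other, the expectation is that the step of a 1.0-fold higher number from compound 2 to compound 3 (0.01 log units; within the scatter) stays within the scatter as well, with no clear direction. Compound 3 is therefore expected to give about 350 nM in this assay, with a plausible range from 150 nM to 800 nM.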

Compound 3, inhibition constant: 1430 nM
Compound 3: middle estimate off by 4.1-fold (0.61 log units), on the low side, outside the stated range (above it).
By their numbers in this assay, from the lowest: compounds 1 and 2 (each within the scatter of the next); then compound 3.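

In this assay, (2-aminophenyl)carbamoyl in place of 2-(hydroxycarbamoyl)ethyl, on a saturated chain carbon five bonds along the chain from an amide-type nitrogen, gives a 4.2-fold higher number from compound 2 to compound 3 (0.62 log units; beyond the scatter), so the far end of this chain can move the read-out, which the pair of compound 1 and compound 2 did not show. The same difference also reads as 4-(hydroxycarbamoyl)butyl to 2-((2-aminophenyl)carbamoyl)ethyl, so the end group and the chain length change together in this one step and its size cannot be assigned to either alone. No measurement to hand bears on the reason for this step.

Open, from the compounds shown here alone, is how much of the step belongs to the end group and how much to the chain length; a longer chain carrying the same (2-aminophenyl)carbamoyl would separate the two. Also open, going by these compounds, is whether other end groups on the chain of compound 2, such as a carboxylic acid or a primary amine, stay close to the 340 nM of compound 2 or fall away as compound 3 does.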